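The source may report more compounds than this note shows. Statements on the series, on what has been measured and on what is new or still open speak of the compounds shown alone.

Measured in a functional assay on MGC-803 cells (Homo sapiens) for cytotoxicity, read by MTT assay, with a stated time of 48 h; on this read-out higher numbers stand for weaker inhibition and lower numbers for stronger inhibition:
Compound 1 `O=C(CSc1ccccc1)N1N=C(c2cc3ccccc3oc2=O)C[C@@H]1c1ccccc1` gives 22800 nM
Compound 2 `O=C(CSc1ccc([N+](=O)[O-])cc1)N1N=C(c2cc3ccccc3oc2=O)C[C@@H]1c1ccccc1C(F)(F)F` gives 7580 nM
Compound 3 `O=C(CSCc1ccco1)N1N=C(c2cc3ccccc3oc2=O)C[C@@H]1c1ccccc1C(F)(F)F` gives 15700 nM

On these numbers, compound 3 cannot be told apart from compound 1, as the two values lie within the scatter of each other. Compound 3 does stand clear of compound 2. The next compound, compound 4 `O=C(CSc1ccc(Br)cc1)N1N=C(c2cc3ccccc3oc2=O)C[C@@H]1c1ccccc1C(F)(F)F`, differs from compound 3 by one exchange: 4-bromophenyl in place of (furan-2-yl)methyl on a sulfur. In words, 4-bromophenyl stands in place of (furan-2-yl)methyl on a sulfur.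

Among the compounds with values here, one measured step bears directly on this exchange: a 2.1-fold higher number from compound 2 to compound 3 (0.32 log units; beyond the scatter). That step put the same (furan-2-yl)methyl in place of 4-nitrophenyl on a sulfur, so the exchange now considered runs the opposite way, to a different para-free aryl partner, 4-bromophenyl. Within the data shown here, no measured compound shows what 4-bromophenyl itself does in this assay, and compound 1 differs from compound 3 in more than one place, so it offers no clean comparison. A modest step towards a lower number is therefore expected, one that may not clear the scatter. The expected change is a 1.7-fold lower number from compound 3 to compound 4 (0.22 log units; within the scatter). Compound 4 is estimated at 9500 nM, with an expected range from 4500 nM to 19000 nM.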

Compound 4, half-maximal inhibitory concentration: 21300 nM
Estimate against measurement, compound 4: 2.2-fold (0.35 log units) below; measured number outside the range, above it.
By their numbers in this assay, from the lowest: compound 2; then compounds 3, 4 and 1 (each within the scatter of the next).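

In this assay, the exchange on the sulfur gives a 1.4-fold higher number from compound 3 to compound 4 (0.13 log units; within the scatter), so 4-bromophenyl and (furan-2-yl)methyl cannot be told apart at this place, even though one is a six-membered aromatic ring of carbon only and the other a five-membered aromatic ring with 1 hetero atom. Bromo in place of nitro on an aromatic carbon gives a 2.8-fold higher number from compound 2 to compound 4 (0.45 log units; beyond the scatter), which clears the scatter, so among the three compounds that share this core, 4-nitrophenyl alone sets its compound apart, and an aromatic ring on the sulfur is not enough on its own to do so. Nothing available on these compounds accounts for the separation between the nitro and bromo compounds.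

The compounds shown leave open whether this separation belongs to the nitro group alone or would also appear with a nitrile, a methoxy group or an amine in its stead on the same aromatic carbon. They also leave open how a longer chain between the sulfur and the ring, or a carboxylic acid on that ring, would read in this assay.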